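The source may hold more compounds than are shown below. What is called first, only, known or untested is meant among the compounds shown, and "the series" means these compounds.

Measured so far in a functional assay on MCF7 cells (Homo sapiens) for cytotoxicity, read by MTT assay, with a stated time of 72 h; on this read-out lower numbers stand for higher toxicity in this test and higher numbers for lower toxicity in this test:
Compound 1 `CCCCC[Se]c1nc(NCc2ccc(SC)cc2)c2ccccc2n1` — 95300 nM
Compound 2 `CCCCC[Se]c1nc(NCc2ccccc2)c2ccccc2n1` — 99400 nM

Compound 1 holds the lowest of the two numbers; its nearest neighbour, compound 2, is separated from it only by a 1.0-fold higher number from compound 1 to compound 2 (0.02 log units; within the scatter). Compound 3 `CSc1ccc(CNc2nc([Se]C)nc3ccccc23)cc1` differs from compound 1 by hydrogen in place of butyl on a saturated chain carbon bound to a selenium atom. Among the compounds with values here, the single measured step concerns the methylsulfanyl group on an aromatic carbon, not the chain on selenium, so no step in hand bears on this change. With nothing pointing either way, the expected step of a 1.0-fold higher number from compound 1 to compound 3 (0.02 log units; within the scatter) is none beyond the scatter. Compound 3 is therefore estimated at 100000 nM, in a range from 30000 nM to 300000 nM.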

Compound 3, concentration lethal to 50% of the cells: > 100000 nM
Compound 3 ended at the assay's limit; the forecaster's own chance of this, stated with the estimate: 20%; the middle value sits exactly at the limit.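

In this assay compound 3 gives > 100000 nM, which is a limit of the assay and not a number. Within the data shown here, the change from pentyl to methyl on selenium gives an at least 1.0-fold higher number from compound 1 to compound 3 (0.02 log units; that floor lies within the scatter), the first reading at this position, and it shows no move towards higher toxicity in this test. How far the number rises cannot be read past this ceiling: the limit of > 100000 nM in this assay, at which 1 of the 3 values shown sits.

The compounds shown leave open whether a propyl chain, a longer chain, or a chain ending in an amine or a carboxylic acid at this place would bring a lower number.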